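A benzyl amide gives way to a substituted phenyl amide

This account rests on a few compounds, and the source may have more. Where it says the series, first, only, none or still open, it means among the compounds named here.

Compound 1 `CNC(=O)CCSc1ccc2c(/C=C/c3ccccn3)n[nH]c2c1`: > 10000 nM (a limit)
Compound 2 `Cc1ccc(NC(=O)CCSc2ccc3c(/C=C/c4ccccn4)n[nH]c3c2)cc1`: > 10000 nM (a limit)
Compound 3 `O=C(CCSc1ccc2c(/C=C/c3ccccn3)n[nH]c2c1)NCc1cccc(C(F)(F)F)c1`: 8030 nM

All three compounds were tested in an ADME assay on BaF3 cells (Mus musculus) for antiproliferative activity, read by CCK-8 assay, with a stated time of 72 h; on this read-out lower numbers stand for stronger inhibition of growth and higher numbers for weaker inhibition of growth. Among the measured compounds shown here, compound 3 is the only one with a true number, 8030 nM. The other two results are limits of the assay, and the series has to be read against (the limit of > 10000 nM in this assay, at which 2 of the 3 values shown sit).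

Compound 4 `Cc1ccc(NC(=O)CCSc2ccc3c(/C=C/c4ccccn4)n[nH]c3c2)cc1C(F)(F)F` has not yet been measured. Its difference from compound 3 is this: 4-methyl-3-(trifluoromethyl)phenyl in place of 3-(trifluoromethyl)benzyl on an amide-type nitrogen. In it, 4-methyl-3-(trifluoromethyl)phenyl takes the place of 3-(trifluoromethyl)benzyl on an amide-type nitrogen.

The measured steps offer little guidance. There is a step that the two limits leave unreadable from compound 1 to compound 2, then an at least 1.2-fold lower number from compound 1 to compound 3 (0.09 log units; that floor lies within the scatter), and finally an at least 1.2-fold lower number from compound 2 to compound 3 (0.09 log units; that floor lies within the scatter). The last is the closest guide, as it exchanges the group on the same amide-type nitrogen, and the group entering compound 4 also holds the 4-methylphenyl of compound 2.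

None of these steps supports a large expected change in this assay, so nothing beyond the scatter is expected, and the estimated step is a 1.1-fold lower number from compound 3 to compound 4 (0.06 log units; within the scatter). A report of only a limit would be no surprise. The estimate for compound 4 is 7000 nM, with an expected range of 2000 nM to 10000 nM.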

Compound 4, concentration for 50% growth inhibition: 530 nM
Compound 4: the middle estimate sits 13-fold (1.12 log units) above what was measured; measured number below the stated range.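

In this assay, among the compounds shown here, the 4-methyl-3-(trifluoromethyl)phenyl amide brings the first change that clearly exceeds the scatter, a 15-fold lower number from compound 3 to compound 4 (1.18 log units; beyond the scatter), which shows that this amide-type nitrogen is sensitive to how the same atoms are joined in its substituent. Trifluoromethyl in place of hydrogen on an aromatic carbon of the 4-methylphenyl amide gives an at least 18-fold lower number from compound 2 to compound 4 (1.27 log units; beyond the scatter), and the full substituted phenyl group in place of methyl on the nitrogen gives an at least 18-fold lower number from compound 1 to compound 4 (1.27 log units; beyond the scatter), so the 4-methylphenyl group alone is not enough to produce a measurable number here. These last two steps can be read only as floors, and the true sizes remain hidden: the limit of > 10000 nM in this assay, at which 2 of the 4 values shown sit.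

The compounds shown do not settle whether the gain needs both the methyl and the trifluoromethyl on the phenyl ring, or whether 3-(trifluoromethyl)phenyl alone would carry it. They also leave open how a chlorine in place of the trifluoromethyl, an amine such as morpholine on the phenyl ring, or a longer chain leading to the amide carbonyl would affect growth inhibition.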